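Fluoro to propylcarbamoyl on an inactive compound

This account rests on a few compounds, and the source may have more. Where it says the series, first, only, none or still open, it means among the compounds named here.

Going by the values given here, in a functional assay on MCF7 cells (Homo sapiens) for antiproliferative activity, read by CCK-8 assay, with a stated time of 72 h (on this read-out higher numbers stand for weaker inhibition of growth and lower numbers for stronger inhibition of growth), compound 1 (`CC[C@@H]1C(=O)N(C)c2cnc(Nc3ccc(S(=O)(=O)NC)cc3)nc2N1C1CCCC1`) gives 151 nM as the only number so far. Compound 2 (`CC[C@@H]1C(=O)N(C)c2cnc(-n3ccc4cc(F)ccc43)nc2N1C1CCCC1`) is recorded in this assay as "not active" (no number reported) and therefore has no numerical place on this scale. Compound 3 (`CCCNC(=O)c1ccc2c(ccn2-c2ncc3c(n2)N(C2CCCC2)[C@H](CC)C(=O)N3C)c1`) has yet to be measured. The change propylcarbamoyl in place of fluoro on an aromatic carbon puts propylcarbamoyl in place of fluoro on an aromatic carbon and leaves the rest of the structure untouched. Among the compounds with values here, no measured step guides this comparison, and compound 2 offers no number to start from. Even so, a large step towards stronger inhibition of growth is expected in this assay, although compound 3 could also return no number. Compound 1 at 151 nM is the only numerical reference for that expectation. Compound 3 is estimated at 1000 nM within an expected range of 150 nM to 7000 nM on this measure.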

Compound 3, concentration for 50% growth inhibition: 592 nM
Estimate against measurement, compound 3: 1.7-fold (0.23 log units) above; low and high end bracket the measured number.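

In this assay, going by these compounds alone, compound 3 gives 592 nM while compound 2 carries no number, so no step between these two compounds can be read. The compounds shown leave open how far propylcarbamoyl in place of fluoro shifts inhibition of growth. No evidence shown bears on this result.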